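A Trifluoromethyl Step Repeated on a Fluorinated Ring

This account rests on a few compounds, and the source may have more. Where it says the series, first, only, none or still open, it means among the compounds named here.

Compound 1 `CC1=C(/C=C/C(=O)/C=C/c2ccccc2C(F)(F)F)C(C)(C)CCC1O` and compound 2 `CC1=C(/C=C/C(=O)/C=C/c2cc(C(F)(F)F)ccc2C(F)(F)F)C(C)(C)CCC1O` differ in one place: trifluoromethyl in place of hydrogen on an aromatic carbon In a functional assay on LNCaP cells (Homo sapiens) for cytotoxicity, read by MTT assay, with a stated time of 72 h (a higher number here means a weaker inhibitor, a lower number a stronger inhibitor), compound 1 gives 2900 nM and compound 2 gives 3200 nM, so a 1.1-fold higher number from compound 1 to compound 2 (0.04 log units; within the scatter). Compound 3 `CC1=C(/C=C/C(=O)/C=C/c2cccc(F)c2)C(C)(C)CCC1O` and the unmeasured compound 4 `CC1=C(/C=C/C(=O)/C=C/c2cc(F)cc(C(F)(F)F)c2)C(C)(C)CCC1O` share this kind of change: trifluoromethyl in place of hydrogen on an aromatic carbon The surroundings of the place are not the same: in compound 2 the entering group sits para to a trifluoromethyl group, while in compound 4 it sits meta to a fluoro group, so the change is the same kind, not the same. The difference between the core of compound 3 and the core of compound 1 is not broken down here. In this assay compound 3 gives 4400 nM. Because the earlier step of a 1.1-fold higher number from compound 1 to compound 2 (0.04 log units; within the scatter) stayed within the scatter, compound 4 is expected to give 4600 nM, between 2800 nM and 7500 nM. That estimate means a step of a 1.0-fold higher number from compound 3 to compound 4 (0.02 log units; within the scatter), expected to be small.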

Compound 4, half-maximal inhibitory concentration: 1100 nM
Compound 4: middle estimate off by 4.2-fold (0.62 log units), on the high side, outside the stated range (below it).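

In this assay, putting trifluoromethyl in place of hydrogen on the fluoro-bearing ring gives a 4.0-fold lower number from compound 3 to compound 4 (0.60 log units; beyond the scatter), so here the change goes with a stronger inhibitor. The same kind of change did not carry over with the same size from one core to the other: the same change on two cores in this assay, a 1.1-fold higher number (0.04 log units; within the scatter) from compound 1 to compound 2 and a 4.0-fold lower number (0.60 log units; beyond the scatter) from compound 3 to compound 4, 4.4-fold (0.64 log units) apart, beyond the scatter of two such steps. Going by these compounds alone, with only one pair on each core, this shows that the size of the step cannot simply be transferred between these cores, but not which difference between them matters or how the change would behave on any other core.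

The compounds shown leave open whether a different group in the same place, such as a methyl, a nitrile, an amine or a carboxylic acid, would give a similar step.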